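Nitro in place of hydrogen on compound 2

The compounds below may be only part of what the source reports. "The series", "measured", "known", "first", "only" and "open" are said of these compounds alone.

Measured in a functional assay on HO8910 cells (Homo sapiens) for inhibition, read by MTT assay, with a stated time of 24 h, tested at 0.1 ug/mL; on this read-out lower numbers stand for less inhibition of growth and higher numbers for more inhibition of growth at the one concentration tested:
- compound 1 (`CC(=O)SCCC(CCCCC(=O)O)SC(C)=O`) gives "not active" (no number reported)
- compound 2 (`O=C(CCCCC1CCSS1)Nc1cccc(C(F)(F)F)c1`) gives 5%
- compound 3 (`O=C(CCCCC1CCSS1)Nc1ccc(OC(F)(F)F)cc1`) gives 5.53%

Compound 2 (5%) lies within the scatter of compound 3 (5.53%), and compound 1 has no number. Compound 4 (`O=C(CCCCC1CCSS1)Nc1ccc([N+](=O)[O-])c(C(F)(F)F)c1`) differs from compound 2 by nitro in place of hydrogen on an aromatic carbon, ortho to a trifluoromethyl group and para to a large group (nitro in place of hydrogen on an aromatic carbon). Among the compounds with values here, no measured pair shows this change, so no step beyond the scatter is expected in this assay. The estimated a number 2 percentage points higher from compound 2 to compound 4 (within the scatter) is small and towards more inhibition of growth. The estimate for compound 4 is 7% (expected range 0% to 20%).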

Compound 4, percent growth inhibition at one concentration: "not active" (no number reported)
For compound 4 the study gives words and no number; there is nothing to compare the estimate with.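

Within the data shown here, no step from compound 2 to compound 4 can be read in this assay, as compound 4 carries words and no number. The compounds shown leave open how far nitro in place of hydrogen shifts inhibition of growth. No measurement given here bears on this result.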